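The source may report more compounds than this note shows. Statements on the series, on what has been measured and on what is new or still open speak of the compounds shown alone.

Measured compounds in an ADME assay on liver for metabolic stability, with Liver microsome (Homo sapiens) as the target, read by LC-MS, using microsomes, with a stated time of 5 h; on this read-out lower numbers stand for slow clearance and higher numbers for fast clearance:
compound 1, `O[C@H](c1ccccn1)[C@]1(c2ccc(Cl)c(Cl)c2)CCO1`, 66.7 mL/min/kg
compound 2, `C[C@]1(O)C[C@](c2ccc(OC(F)(F)F)cc2)([C@H](O)c2ccccn2)C1`, 50 mL/min/kg
compound 3, `C[C@]1(O)C[C@](c2ccc(C(F)(F)F)cc2)([C@H](O)c2ccccn2)C1`, 33.3 mL/min/kg

Compound 2 sits among three values that all lie within the scatter of one another, so no ordering among them can be read. For the measured compounds named here, the single measured step, a 1.5-fold lower number from compound 2 to compound 3 (0.18 log units; within the scatter), concerns a substituent swap on an aromatic carbon and not configuration. Compound 4, `C[C@]1(O)C[C@@](c2ccc(OC(F)(F)F)cc2)([C@H](O)c2ccccn2)C1`, relates to compound 2 as follows: the two compounds have the same atoms and bonds and differ only in configuration as drawn: 2 of 3 stereo elements differ; a stereocentre at a saturated ring carbon is drawn S in compound 2 and R in compound 4; a stereocentre at a saturated ring carbon is drawn r in compound 2 and s in compound 4. Going by the values given here, no measured pair isolates a change of configuration, so the data give no direction for this step. Compound 4 is therefore expected to give about 50 mL/min/kg in this assay, with a range from 25 mL/min/kg to 100 mL/min/kg. That estimate means a step of no change at the digits printed from compound 2 to compound 4 (within the scatter), expected to stay within the scatter.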

Compound 4, clearance: 66.7 mL/min/kg
Compound 4: middle estimate off by 1.3-fold (0.13 log units), on the low side; the measured number falls inside the stated range.
By their numbers in this assay, from the lowest: compounds 3, 2, 1 and 4 (each within the scatter of the next).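

In this assay, the measured change of configuration gives a 1.3-fold higher number from compound 2 to compound 4 (0.13 log units; within the scatter). Unlike the earlier step, which exchanged a substituent on an aromatic carbon, this pair isolates configuration, with 2 of 3 stereo elements differing, and no difference beyond the scatter can be read across it. The step can be assigned to configuration alone: the fact that compounds 2 and 4 differ only in the configuration as drawn

The compounds shown leave open whether the same change of configuration would read alike with trifluoromethyl in place of trifluoromethoxy. They also leave open how an amine or a carboxylic acid on the aromatic carbon would compare.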